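The source may hold more compounds than are shown below. What is called first, only, known or untested is meant among the compounds shown, and "the series" means these compounds.

Within the data shown here, in a functional assay on L5178Y cells (Mus musculus) for antiproliferative activity, read by MTT assay (a lower number here means a stronger inhibitor, a higher number a weaker inhibitor), compound 1 `CC(=O)c1ccc(OCCCN2CCN(c3ncccn3)CC2)cc1` gives 53.2 nM, the higher of the two numbers measured so far. Compound 2 `CC(C)(C)c1ccc(OCCCN2CCN(c3ncccn3)CC2)cc1` gives 25.6 nM. Among the measured compounds shown here, the only measured step is a 2.1-fold lower number from compound 1 to compound 2 (0.32 log units; beyond the scatter), a modest change made at the acetyl group. Compound 3 `CC(=O)c1ccc(OCCCN2CCN(c3ccccn3)CC2)cc1` keeps that acetyl group and differs from compound 1 elsewhere: pyridin-2-yl in place of pyrimidin-2-yl on an amine nitrogen in a ring. This puts pyridin-2-yl in place of pyrimidin-2-yl on an amine nitrogen in a ring. For the measured compounds named here, no measured step touches that place, so the data offer no direct guide, and the step at the acetyl group sets only a rough scale for a single change. No shift beyond the scatter is therefore expected in this assay, in either direction. The estimated change is a 1.1-fold lower number from compound 1 to compound 3 (0.03 log units; within the scatter). For compound 3, the expected value is 50 nM, with an estimated range from 20 nM to 125 nM.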

Compound 3, half-maximal inhibitory concentration: 27.1 nM
Compound 3: the middle estimate sits 1.8-fold (0.27 log units) above what was measured; measured number inside the range.
By their numbers in this assay, from the lowest: compounds 2, 3 and 1 (each within the scatter of the next, the first and the last beyond it).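

In this assay, among these compounds, pyridin-2-yl in place of pyrimidin-2-yl on the amine nitrogen in a ring gives a 2.0-fold lower number from compound 1 to compound 3 (0.29 log units; within the scatter) and so provides the first reading at this position. In this single pair, an aromatic ring with 1 hetero atom replacing one with 2 hetero atoms leaves compound 3 within the scatter of compound 1, so the data show no clear preference between these two groups. No measured evidence bears on this result.

The compounds shown leave open how phenyl or a simple methyl group would read on that same amine nitrogen. As far as these compounds go, it also remains open whether tert-butyl in place of acetyl, the change behind a 2.1-fold lower number from compound 1 to compound 2 (0.32 log units; beyond the scatter), would give a similar step with pyridin-2-yl on that nitrogen.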